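Glycine to threonine-type side chain on the second core

The compounds below may be only part of what the source reports. "The series", "measured", "known", "first", "only" and "open" are said of these compounds alone.

Compound 3 `CC1=CCC[C@](C)(CC/C(C)=C/CC2=C(O)C(=O)C=C(NCC(=O)O)C2=O)[C@@H]1C` gives 3.5 ug/mL in an ADME assay on L1210 cells (Mus musculus) for cytotoxicity, with a stated time of 48 h (a lower number here means a stronger inhibitor, a higher number a weaker inhibitor), the lowest of the two plain numbers shown. Compound 1 `C=C1[C@H](C)CCC[C@]1(C)CC/C(C)=C/CC1=C(O)C(=O)C=C(N[C@@H](C(=O)O)[C@H](C)O)C1=O` gives 4.6 ug/mL in this assay, and the two compounds sit within the scatter of each other. Compound 2 `C=C1[C@H](C)CCC[C@]1(C)CC/C(C)=C/CC1=C(O)C(=O)C=C(N[C@@H](CO)C(=O)O)C1=O` returns only a limit of > 10 ug/mL in this assay (the limit of > 10 ug/mL in this assay, at which 1 of the 3 values shown sits). Among the measured compounds shown here, the one measured step, an at least 2.1-fold higher number from compound 1 to compound 2 (0.33 log units; beyond the scatter), concerns a different change from the one now in question and so bears on it only loosely. Compound 4 `CC1=CCC[C@](C)(CC/C(C)=C/CC2=C(O)C(=O)C=C(N[C@H](C(=O)O)[C@@H](C)O)C2=O)[C@@H]1C` carries 1-hydroxyethyl in place of hydrogen on a saturated chain carbon bound to an amine nitrogen and a carbonyl carbon. For the measured compounds named here, no measured step covers this change; the values of compounds 1 and 3 suggest little movement. Compound 4 is therefore expected at 4 ug/mL, between 2 ug/mL and 9 ug/mL, a step of a 1.1-fold higher number from compound 3 to compound 4 (0.06 log units; within the scatter) that is expected to stay within the scatter.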

Compound 4, half-maximal inhibitory concentration: > 10 ug/mL
Compound 4 ended at the assay's limit (the forecaster's own chance of this, stated with the estimate: 15%); middle value at least 2.5-fold (0.39 log units) away from the limit.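

In this assay, 1-hydroxyethyl in place of hydrogen on a saturated chain carbon bound to an amine nitrogen and a carbonyl carbon weakens the core of compound 3 (an at least 2.8-fold higher number from compound 3 to compound 4 (0.45 log units; beyond the scatter)). Among the compounds shown here, the earlier compounds held no step for this change, and the only earlier step (an at least 2.1-fold higher number from compound 1 to compound 2 (0.33 log units; beyond the scatter)) concerned a different one. Compound 4 gives only a limit, and such limits now recur: the limit of > 10 ug/mL in this assay, at which 2 of the 4 values shown sit.

Going by these compounds, the full size of the step stays open. So does whether a methyl group or a longer alkyl chain at this carbon would do the same.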